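This account rests on a few compounds, and the source may have more. Where it says the series, first, only, none or still open, it means among the compounds named here.

Of the compounds shown here, three sharing one core have been measured in a functional assay on MCF7 cells (Homo sapiens) for antiproliferative activity, read by CCK-8 assay, with a stated time of 72 h; on this read-out lower numbers stand for stronger inhibition of growth and higher numbers for weaker inhibition of growth. Compound 1 `CC[C@@H]1C(=O)N(C)c2cnc(Nc3ccc(S(=O)(=O)NC4CCCC4)cc3)nc2N1C1CCCC1` gives 688 nM. Compound 2 `CC[C@@H]1C(=O)N(C)c2cnc(Nc3ccc(S(N)(=O)=O)cc3)nc2N1C1CCCC1` gives 394 nM, and compound 3 `CC[C@@H]1C(=O)N(C)c2cnc(Nc3ccc(S(=O)(=O)NCC(C)C)cc3)nc2N1C1CCCC1` gives 403 nM. Among these three numbers compound 3 stands second highest; its nearest neighbour is compound 2, and the step of a 1.0-fold higher number from compound 2 to compound 3 (0.01 log units; within the scatter) lies within the scatter, as does the step of a 1.7-fold lower number from compound 1 to compound 3 (0.23 log units; within the scatter) to its furthest neighbour.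

Compound 4 `CC[C@@H]1C(=O)N(C)c2cnc(Nc3ccc(S(=O)(=O)NC)cc3)nc2N1C1CCCC1` has not been measured. It differs from compound 3 by hydrogen in place of isopropyl on a saturated chain carbon bound to a sulfonamide nitrogen. The measured steps that bear on this change are those on the sulfonamide nitrogen: a 1.7-fold lower number from compound 1 to compound 2 (0.24 log units; within the scatter), a 1.7-fold lower number from compound 1 to compound 3 (0.23 log units; within the scatter) and a 1.0-fold higher number from compound 2 to compound 3 (0.01 log units; within the scatter), each within the scatter, so the substituent on that nitrogen has not moved the number beyond the scatter across these three compounds. Methyl falls between hydrogen and isobutyl, and no step beyond the scatter is therefore expected. For compound 4 the expected step is a 1.0-fold lower number from compound 3 to compound 4 (0.00 log units; within the scatter). Compound 4 is expected to give 400 nM in this assay, with a range from 200 nM to 800 nM.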

Compound 4, concentration for 50% growth inhibition: 151 nM
For compound 4 the middle estimate is 2.6-fold (0.42 log units) above the measured one; the whole stated range lies above it.
By their numbers in this assay, from the lowest: compound 4; then compounds 2, 3 and 1 (each within the scatter of the next).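

In this assay, the substituent on the sulfonamide nitrogen now moves the number beyond the scatter: methyl in place of isobutyl gives a 2.7-fold lower number from compound 3 to compound 4 (0.43 log units; beyond the scatter), methyl in place of hydrogen gives a 2.6-fold lower number from compound 2 to compound 4 (0.42 log units; beyond the scatter), and methyl in place of cyclopentyl gives a 4.6-fold lower number from compound 1 to compound 4 (0.66 log units; beyond the scatter). The result does not follow a steady trend from hydrogen through methyl to isobutyl, since the two outer groups remain level, with a 1.0-fold higher number from compound 2 to compound 3 (0.01 log units; within the scatter), while methyl stands apart from both. Nothing available explains why methyl behaves differently from the other three groups.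

Going by these compounds, it remains open whether this gain is particular to methyl or would extend to an ethyl or propyl chain on the same nitrogen. A second methyl on that nitrogen would test whether the remaining nitrogen hydrogen matters to the result.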